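Replacing ethoxymethyl with 5-methylpyridin-2-yl: a cytotoxicity limit case

This account rests on a few compounds, and the source may have more. Where it says the series, first, only, none or still open, it means among the compounds named here.

Measured so far in an ADME assay on HEK293 cells (Homo sapiens) for cytotoxicity, read by ATP content, with a stated time of 6 h; on this read-out lower numbers stand for higher toxicity in this test and higher numbers for lower toxicity in this test:
- compound 1 `COCCNc1nc(N)nc2ccn(Cc3ccccn3)c12`: > 24000 nM, a limit
- compound 2 `COCCCNc1nc(N)nc2ccn(Cc3ccccn3)c12`: > 24000 nM, a limit
- compound 3 `CCOCCNc1nc(N)nc2ccn(Cc3ccccn3)c12`: > 24000 nM, a limit

Compound 3 gives only a limit, > 24000 nM, and compounds 1 and 2 likewise offer no number. Going by the values given here, the whole series so far is described by the limit of > 24000 nM in this assay, at which 3 of the 3 values shown sit.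

Compound 4 `Cc1ccc(CNc2nc(N)nc3ccn(Cc4ccccn4)c23)nc1` has not yet been measured in this assay. It differs from compound 3 in one place: 5-methylpyridin-2-yl in place of ethoxymethyl on a saturated chain carbon bound to a nitrogen on an aromatic ring. In words, this is 5-methylpyridin-2-yl in place of ethoxymethyl on a saturated chain carbon bound to a nitrogen on an aromatic ring.

The measured steps alter only the ether chain, and none of them brings a ring to this place. They are a step that the two limits leave unreadable from compound 1 to compound 2, a step that the two limits leave unreadable from compound 1 to compound 3 and a step that the two limits leave unreadable from compound 2 to compound 3. Their sizes therefore give no measure for the new change, and they suggest no direction for it.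

With no readable step to draw on, no change beyond the scatter is expected, although a fall from the limit of compound 3 cannot be excluded. The expected outcome is a number no higher from compound 3 to compound 4 (the limit leaves the size open). For compound 4 the estimated value is 24000 nM, with an expected range from 12000 nM to 48000 nM.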

Compound 4, half-maximal cytotoxic concentration: > 24000 nM
Compound 4 ended at the assay's limit; the forecaster's own chance of this, stated with the estimate: 75%; the middle value sits exactly at the limit.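

In this assay compound 4 gives > 24000 nM, which is a limit. No step to compound 4 from compound 1, compound 2 or compound 3 can be read, and the series rests on a single boundary: the limit of > 24000 nM in this assay, at which 4 of the 4 values shown sit.

The compounds shown leave open whether 5-methylpyridin-2-yl in place of ethoxymethyl changes the read-out at all, and in which direction.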